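Sulfur for oxygen on a core with no measured potency

This account rests on a few compounds, and the source may have more. Where it says the series, first, only, none or still open, it means among the compounds named here.

Measured so far:
compound 1, `Nc1ncnc2c1ccn2COCCO`, a limit of > 320000 nM in an ADME assay on KB cells (Homo sapiens) for cytotoxicity; a lower number here means a stronger inhibitor, a higher number a weaker inhibitor
compound 2, `NC(=O)c1cn(COCCO)c2ncnc(N)c12`, a limit of > 100000 nM in this assay

Neither value is a number. Compound 1 sits at a limit of the assay (the limit of > 320000 nM in this assay, at which 1 of the 2 values shown sits). Compound 2 likewise sits at a limit (the limit of > 100000 nM in this assay, at which 1 of the 2 values shown sits), so its standing on this assay is known only as a bound, not as a position. The change between them, carbamoyl in place of hydrogen on an aromatic carbon, gives a step that the two limits leave unreadable from compound 1 to compound 2, which cannot be sized because both ends are limits.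

Compound 3, `NC(=S)c1cn(COCCO)c2ncnc(N)c12`, differs from compound 2 by a group of 3 heavy atoms (1 carbon, 1 nitrogen, 1 sulfur; no ring) in place of a group of 3 heavy atoms (1 carbon, 1 nitrogen, 1 oxygen; no ring), on an aromatic carbon. Going by the values given here, the one measured step bears on it only in kind, not in size, since it is unreadable. With both measured compounds at limits, the expectation is that compound 3 is also expected to show no measurable inhibition, and the step of a number no higher from compound 2 to compound 3 (the limit leaves the size open) is expected to stay within the scatter. Compound 3 is therefore estimated at 100000 nM, with a range from 30000 nM to 320000 nM, most likely reported again as a limit.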

Compound 3, half-maximal inhibitory concentration: > 100000 nM
Compound 3 was reported as a limit (the forecaster's own chance of this, stated with the estimate: 75%); the middle value sits exactly at the limit.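

Going by these compounds alone, compound 1, compound 2 and compound 3 each sit at a limit in this assay rather than at a number, so no step among them can be read. The compounds shown leave open whether any of the three has a measurable potency in this assay, and whether exchanging oxygen for sulfur in the carbamoyl group changes it.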